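A few compounds are considered here, and "the series" means these few. Any claim that something is new, unique, unknown or untested is made for them only; others in the source may bear on it.

Three compounds of the series have numbers in an assay on isolated protein for inhibition of Leucine-rich repeat serine/threonine-protein kinase 2 (Homo sapiens), read by TR-FRET and LanthaScreen, with stated times of 50 min and 30 min, in the presence of a further agent that is not named here; a lower number here means a stronger inhibitor, a higher number a weaker inhibitor. Compound 1 `CN(C)c1c(C#N)c2c(N)ncnc2n1C` gives 4620 nM. Compound 3 `C[C@@H]1CCCN1c1cc2c(N)ncnc2n1C` gives 6830 nM, which lies within the usual scatter of the number for compound 1, so the two cannot be told apart. Compound 2 `Cn1c(-c2cccc(F)c2F)c(C#N)c2c(N)ncnc21` gives 572 nM, a lower number than compound 1 by a gap beyond the scatter. Compound 1 thus stands second highest of the three numbers, separated from compound 2 but not from compound 3.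

Compound 4 `Cn1c(-c2ccccc2)c(C#N)c2c(N)ncnc21` has not yet been measured in this assay. Relative to compound 1 it differs in one place: phenyl in place of dimethylamino on an aromatic carbon. Among the measured compounds shown here, no step between measured compounds covers exactly this exchange. A move toward a lower number is nonetheless expected, because compound 2 gives 572 nM while bearing a six-membered aromatic ring of carbon only at the same place. The step from compound 1 to compound 4 is expected to be a 3.6-fold lower number from compound 1 to compound 4 (0.55 log units; beyond the scatter), lower beyond the scatter but short of the full gap to compound 2. Compound 4 is estimated at 1300 nM, with a range from 450 nM to 3800 nM.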

Compound 4, half-maximal inhibitory concentration: 1260 nM
Compound 4: middle estimate off by 1.0-fold (0.01 log units), on the high side; low and high end bracket the measured number.
By their numbers in this assay, from the lowest: compound 2; then compound 4; then compounds 1 and 3 (each within the scatter of the next).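

In this assay, among the compounds shown here, the exchange on the aromatic carbon next to the ring nitrogen gives a 3.7-fold lower number from compound 1 to compound 4 (0.56 log units; beyond the scatter), the only step at this position that can be read directly. With the cyano and methyl groups kept in place, a lower number therefore does not require fluorine on the phenyl ring, although compound 2 at 572 nM and compound 4 at 1260 nM show that the ring's substitution remains a further variable. Nothing measured here explains the shift.

On these data alone, it remains open how a pyridine ring, a morpholine or a phenyl bearing a single fluorine would read at this position. The contribution of the cyano group beside a phenyl is also unresolved, as no compound shown pairs phenyl with a hydrogen or an amide on that neighbouring ring atom.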